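The source may hold more compounds than are shown below. What is called first, only, known or untested is meant among the compounds shown, and "the series" means these compounds.

Compound 1, `COc1ccccc1N1CCN(CCCN(CC2CCCCC2)S(=O)(=O)c2cccc3cccnc23)CC1`, gives 24 nM in an assay on CHO cells for displacement of a labelled ligand from 5-hydroxytryptamine receptor 7 (Homo sapiens); on this read-out lower numbers stand for stronger inhibition and higher numbers for weaker inhibition.
Compound 2, `O=S(=O)(c1cccc2cccnc12)N(CCCN1CCN(c2ccc(Cl)c(Cl)c2)CC1)CC1CCCCC1`, gives 2300 nM in this assay.
Compound 3, `O=S(=O)(c1ccc2ccccc2c1)N(CCCN1CCN(c2cccc(C(F)(F)F)c2)CC1)CC1CC1`, gives 342 nM in this assay.

Among these three, compound 3 stands second highest: compound 2 lies above it with a number that is beyond the scatter, and compound 1 lies well below it, also beyond the scatter. Among the measured compounds shown here, the only step between compounds that differ in one place is a 96-fold higher number from compound 1 to compound 2 (1.98 log units; beyond the scatter), a change on the amine nitrogen in the ring, not on the sulfonyl sulfur.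

Compound 4, `O=S(=O)(c1cccc2cccnc12)N(CCCN1CCN(c2cccc(C(F)(F)F)c2)CC1)CC1CC1`, is not yet measured. It differs from compound 3 by quinolin-8-yl in place of naphthalen-2-yl on a sulfonyl sulfur. For the measured compounds named here, no measured pair isolates this change: compounds 1 and 2 both carry quinolin-8-yl but differ from compound 3 in the group on the ring amine as well, so their values say nothing direct about the sulfonyl group alone. That quinolin-8-yl appears in the lowest and in the highest number shown leaves the direction open.

Compound 4 is therefore expected to sit near compound 3, with a 1.7-fold lower number from compound 3 to compound 4 (0.23 log units; within the scatter) as the estimated step, most likely small. The estimate for compound 4 is 200 nM, within a range from 40 nM to 1000 nM.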

Compound 4, half-maximal inhibitory concentration: 6.3 nM
Compound 4: middle estimate off by 32-fold (1.50 log units), on the high side; the whole stated range lies above it.
By their numbers in this assay, from the lowest: compound 4; then compound 1; then compound 3; then compound 2.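

On the sulfonyl sulfur, with the rest of the molecule unchanged, quinolin-8-yl in place of naphthalen-2-yl gives in this assay a 54-fold lower number from compound 3 to compound 4 (1.73 log units; beyond the scatter) and so shows that this position can shift the number strongly, just as the group on the ring amine did in the earlier step of a 96-fold higher number from compound 1 to compound 2 (1.98 log units; beyond the scatter) with its large change. The exchange itself is small on paper: both groups have 10 heavy atoms and two six-membered aromatic rings, but quinolin-8-yl has one ring nitrogen in place of a ring carbon and so counts one hydrogen-bond acceptor where naphthalen-2-yl counts none. Nothing available here explains how this single atom change produces so large a step.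

The compounds shown leave open whether the ring nitrogen must sit where quinolin-8-yl places it, which a quinolin-5-yl or an isoquinolin-5-yl group on the sulfonyl sulfur would test. They also leave open whether the same exchange gives a step of similar size when the ring amine carries 2-methoxyphenyl or 3,4-dichlorophenyl, since neither of those compounds has a naphthalen-2-yl partner here.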